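Replacing Morpholine with Piperidine in Compound 1

The source may hold more compounds than are shown below. What is called first, only, known or untested is meant among the compounds shown, and "the series" means these compounds.

Compound 1 `COc1ccc2occ(CSC(=S)N3CCOCC3)c(=O)c2c1`: 11800 nM
Compound 2 `O=c1c(SC(=S)N2CCCCC2)coc2ccc(Cl)cc12`: > 25000 nM
Compound 3 `O=c1c(CSC(=S)N2CCOCC2)coc2ccccc12`: 4000 nM

These values come from a functional assay on MCF7 cells (Homo sapiens) for antiproliferative activity, read by MTT assay, with a stated time of 72 h; on this read-out higher numbers stand for weaker inhibition and lower numbers for stronger inhibition. Of the two numbers given, compound 1 holds the higher; its nearest neighbour is compound 3, and a 3.0-fold lower number from compound 1 to compound 3 (0.47 log units; beyond the scatter). Compound 2 sits at the limit of > 25000 nM in this assay, at which 1 of the 3 values shown sits. Compound 4 `COc1ccc2occ(CSC(=S)N3CCCCC3)c(=O)c2c1` has not been measured; it differs from compound 1 by piperidin-1-yl in place of morpholin-4-yl on a thiocarbonyl carbon. Going by the values given here, no measured step tests this exchange: compound 1 and compound 3 differ only by the methoxy, and compound 2 carries piperidin-1-yl but also differs from compound 1 elsewhere, so its limit says nothing about this one change. Among the compounds with values here, with no step to lean on, the expectation for compound 4 is no shift beyond the scatter, a 1.0-fold higher number from compound 1 to compound 4 (0.01 log units; within the scatter). Compound 4 is therefore estimated at 12000 nM, with a range from 4000 nM to 36000 nM.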

Compound 4, half-maximal inhibitory concentration: > 40000 nM
Compound 4 was reported as a limit (the forecaster's own chance of this, stated with the estimate: 30%); at least 3.3-fold (0.52 log units) between middle value and limit.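

In this assay, piperidin-1-yl in place of morpholin-4-yl on a thiocarbonyl carbon gives an at least 3.3-fold higher number from compound 1 to compound 4 (0.53 log units; beyond the scatter), the first single change read at this place. Compound 4 is reported as a limit of the assay, not as a number: the limit of > 40000 nM in this assay, at which 1 of the 4 values shown sits. Going by these compounds alone, compound 1 and compound 4 differ only in the ring oxygen of morpholin-4-yl, and the compound that carries this oxygen is the one with a measured number.

On these data alone, how a piperazin-1-yl ring or an open-chain dimethylamino group would read at this place remains open. So does whether the step holds on the core of compound 3, without the methoxy.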